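Swapping the Nitrophenyl Arm in a Disulfide-Isomerase Inhibitor Series

This account rests on a few compounds, and the source may have more. Where it says the series, first, only, none or still open, it means among the compounds named here.

Of the compounds shown here, two have so far been measured in an assay for inhibition of protein disulfide-isomerase (Homo sapiens), with a stated time of 1 h; a lower number here means a stronger inhibitor, a higher number a weaker inhibitor. Compound 1, `Cc1ccnc(NC(c2ccc([N+](=O)[O-])cc2)c2ccc3cccnc3c2O)c1`, gives 530 nM. Compound 2, `Oc1ccc2[nH]ncc2c1C(c1ccc(F)cc1)N1CCCCC1`, gives 350 nM. Among the measured compounds shown here, compound 1 therefore carries the higher of the two numbers, but its only neighbour, compound 2, sits within the usual scatter of it, so the two values cannot be told apart. No pair of these compounds differs in just one place, and no measured step is available.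

Compound 3, `Cc1ccnc(NC(c2ccccc2F)c2ccc3cccnc3c2O)c1`, is not yet measured. It differs from compound 1 as follows: 2-fluorophenyl in place of 4-nitrophenyl on a saturated chain carbon bound to an aromatic carbon and a nitrogen on an aromatic ring. For the measured compounds named here, with no measured step to lean on, the author expects the step of a 1.3-fold higher number from compound 1 to compound 3 (0.12 log units; within the scatter) to be a small weakening, possibly no larger than the scatter itself. The estimate for compound 3 in this assay is 700 nM, with a range from 250 nM to 2000 nM.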

Compound 3, half-maximal inhibitory concentration: 880 nM
Beside the measured number, compound 3's estimate is 1.3-fold (0.10 log units) below it; the range from low to high includes it.
By their numbers in this assay, from the lowest: compounds 2, 1 and 3 (each within the scatter of the next, the first and the last beyond it).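

In this assay, among the compounds shown here, the first measured step at this position is a 1.7-fold higher number from compound 1 to compound 3 (0.22 log units; within the scatter), so 2-fluorophenyl can take the place of 4-nitrophenyl on this saturated chain carbon with no change that can be told from the scatter. The hydrogen-bond acceptors counted on 4-nitrophenyl are absent from 2-fluorophenyl, and the number for compound 3 still stays within the scatter of that for compound 1, which shows that, in this one pair, those acceptors are not needed to hold the value in this range. Nothing available explains the size of this step.

This single step changes both the substituent and its ring position, so it cannot separate the two, and 4-fluorophenyl or 2-nitrophenyl would be needed to do that. From the compounds shown here alone, how an unsubstituted phenyl or a phenyl bearing a carboxylic acid would behave at this position remains open.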